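The compounds below may be only part of what the source reports. "The series", "measured", "known", "first", "only" and "open" are said of these compounds alone.

Of the compounds shown here, three sharing one core have been measured in a functional assay on HCT-116 cells (Homo sapiens) for inhibition, read by MTT assay, with a stated time of 48 h; a lower number here means a stronger inhibitor, a higher number a weaker inhibitor. Compound 1 `O=C1N/C(=N\Cc2ccccc2)S/C1=C1/CCNC(=O)c2[nH]ccc21` gives 49700 nM. Compound 2 `O=C1N/C(=N\Cc2ccccc2Cl)S/C1=C1/CCNC(=O)c2[nH]ccc21` reaches only a limit of the assay, > 50000 nM. Among the measured compounds shown here, compound 3 `Cc1ccc(C/N=C2\NC(=O)/C(=C3\CCNC(=O)c4[nH]ccc43)S2)cc1` gives 4760 nM, the lowest number in this assay so far.

Compound 4 `O=C1N/C(=N\Cc2ccc(F)cc2)S/C1=C1/CCNC(=O)c2[nH]ccc21` differs from compound 3 by one substitution, fluoro in place of methyl on an aromatic carbon, para to a large group, so that 4-methylphenyl becomes 4-fluorophenyl. For the measured compounds named here, no measured step places fluoro on this ring. The closest evidence is a 10-fold lower number from compound 1 to compound 3 (1.02 log units; beyond the scatter), which adds the same methyl that compound 4 gives up. The chloro steps are less informative: a number no lower from compound 1 to compound 2 (the limit leaves the size open) has no readable size, and an at least 10-fold lower number from compound 2 to compound 3 (1.02 log units; beyond the scatter) changes the position as well as the group. Compound 4 is therefore expected to lose part, but not all, of the gain seen in compound 3, and the expected change is a 2.9-fold higher number from compound 3 to compound 4 (0.47 log units; beyond the scatter). For compound 4, the estimated value is 14000 nM, with an expected range from 4000 nM to 45000 nM.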

Compound 4, half-maximal inhibitory concentration: 16900 nM
For compound 4 the middle estimate is 1.2-fold (0.08 log units) below the measured one; the measured number falls inside the stated range.
By their numbers in this assay, from the lowest: compound 3; then compound 4; then compound 1. At a limit, above all of these: compound 2.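

With fluoro on an aromatic carbon para to a large group, the number still falls relative to the unsubstituted benzyl compound: a 2.9-fold lower number from compound 1 to compound 4 (0.47 log units; beyond the scatter). Fluoro gives a smaller gain than methyl at the same place, a 3.6-fold higher number from compound 3 to compound 4 (0.55 log units; beyond the scatter), so among compound 1, compound 3 and compound 4 the outcome depends on which group sits there and not only on whether the place is filled. The comparison with the chlorinated compound, an at least 2.9-fold lower number from compound 2 to compound 4 (0.47 log units; beyond the scatter), is only a bound, since it starts from a limit: the limit of > 50000 nM in this assay, at which 1 of the 4 values shown sits.

Going by these compounds, what a methoxy group, an amine or a trifluoromethyl group would do on that same aromatic carbon stays open. So does whether chloro placed there would behave like fluoro and methyl, or whether any group could bring the number below that of compound 3, 4760 nM.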